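This account rests on a few compounds, and the source may have more. Where it says the series, first, only, none or still open, it means among the compounds named here.

Values in an ADME assay on MRC5 cells (Homo sapiens) for cytotoxicity, read by fluorescence and resazurin assay, with a stated time of 3 days; on this read-out higher numbers stand for weaker inhibition and lower numbers for stronger inhibition:
- Compound 1 `Cc1cn(C2CCN(Cc3cccc(Oc4ccc(Cl)cc4)c3)CC2)c(=O)[nH]c1=O`: 25100 nM
- Compound 2 `Cc1ccc(Oc2cccc(CN3CCC(n4cc(C)c(=O)[nH]c4=O)CC3)c2)cc1`: > 64000 nM, a limit of the assay and not a number
- Compound 3 `Cc1cn(C2CCN(Cc3cccc(Oc4cccc(F)c4)c3)CC2)c(=O)[nH]c1=O`: > 64000 nM, a limit of the assay and not a number

Compound 3 has no exact number, only the limit > 64000 nM. This is the limit of > 64000 nM in this assay, at which 2 of the 3 values shown sit.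

Compound 4 `Cc1cn(C2CCN(Cc3cccc(Oc4cccnc4)c3)CC2)c(=O)[nH]c1=O` keeps the shared core and changes one group, with pyridin-3-yl in place of 3-fluorophenyl on an oxygen on an aromatic ring.

The measured steps nearest to this change all alter the same group on that oxygen. Replacing 4-chlorophenyl with 3-fluorophenyl gave an at least 2.5-fold higher number from compound 1 to compound 3 (0.40 log units; beyond the scatter). Methyl in place of chloro gave an at least 2.5-fold higher number from compound 1 to compound 2 (0.40 log units; beyond the scatter). The remaining comparison is a step that the two limits leave unreadable from compound 2 to compound 3. For the measured compounds named here, no measured compound carries pyridin-3-yl, so these steps are only a loose guide. Going by the values given here, only compound 1 gave a number, at 25100 nM, and it is the one compound with a chloro group. Compound 4 has none, so it is expected to stay near the limit, with no clear change from compound 3 in this assay. The expected step is a number no higher from compound 3 to compound 4 (the limit leaves the size open).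

The estimate for compound 4 is 64000 nM, with an expected range from 30000 nM to 100000 nM.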

Compound 4, half-maximal inhibitory concentration: > 64000 nM
Compound 4: only a limit was reported; the forecaster's own chance of this, stated with the estimate: 75%; the middle value lies on the limit itself.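

In this assay, exchanging the 4-chlorophenyl group on the oxygen for pyridin-3-yl gives an at least 2.5-fold higher number from compound 1 to compound 4 (0.40 log units; beyond the scatter). For the compounds shown here, this extends the earlier picture: the group on that oxygen can now be a ring with a hetero atom, not only a ring of carbon, and the result still parts from compound 1 in the same direction, leaving compound 1 as the only compound here with an exact number. The steps among compound 2, compound 3 and compound 4 cannot be read, because all three stand at the same limit of the assay and no order among them can be drawn: the limit of > 64000 nM in this assay, at which 3 of the 4 values shown sit.

Going by these compounds, a 3-chlorophenyl group on that oxygen would help to separate the effect of the chloro group from the effect of where it sits on the ring, and that question stays open. On these data alone, how a bromo or a methoxy group in that place would read, and how far compound 2, compound 3 and compound 4 really lie past the limit, also stay open.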